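Swapping an aryl group for methyl on a fused core

The source may hold more compounds than are shown below. What is called first, only, known or untested is meant among the compounds shown, and "the series" means these compounds.

Compound 3 `Cc1nc2c3ccccc3ccc2c2nc3c(ccc4ccccc43)c(-c3ccccc3Cl)c12` gives the smallest of three numbers in a functional assay, with a stated time of 90 s (on this read-out higher numbers stand for weaker inhibition and lower numbers for stronger inhibition), where compound 3 shows 170 ug/mL, though every step to it lies within the scatter. Compound 1 `COc1ccc(-c2c3ccc4ccccc4c3nc3c2c(C)nc2c4ccccc4ccc32)cc1` gives 176 ug/mL in this assay, and compound 2 `Cc1nc2c3ccccc3ccc2c2nc3c(ccc4ccccc43)c(-c3cccc4ccccc34)c12` gives 179 ug/mL; the steps of a 1.0-fold lower number from compound 1 to compound 3 (0.02 log units; within the scatter) and a 1.1-fold lower number from compound 2 to compound 3 (0.02 log units; within the scatter) leave compound 3 indistinguishable from either. Compound 4 `Cc1nc2c3ccccc3ccc2c2nc3c(ccc4ccccc43)c(C)c12` differs from compound 3 in one place: methyl in place of 2-chlorophenyl on an aromatic carbon. The methyl sits on an aromatic carbon of a six-membered aromatic ring with 1 nitrogen, part of a fused or bridged system of six rings, opposite the ring nitrogen. Among the compounds with values here, three measured steps concern this same carbon, a 1.0-fold lower number from compound 1 to compound 3 (0.02 log units; within the scatter), a 1.1-fold lower number from compound 2 to compound 3 (0.02 log units; within the scatter) and a 1.0-fold higher number from compound 1 to compound 2 (0.01 log units; within the scatter), all within the scatter, so three different aryl groups gave the same read-out. None of them removed the aryl ring altogether, so the present change is of a new kind and the data give less footing. The author expects a step of a 1.0-fold higher number from compound 3 to compound 4 (0.01 log units; within the scatter), not beyond the scatter, and estimates for compound 4 a value of 175 ug/mL in this assay, with a range from 90 ug/mL to 340 ug/mL.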

Compound 4, half-maximal inhibitory concentration: 195 ug/mL
Estimate against measurement, compound 4: 1.1-fold (0.05 log units) below; low and high end bracket the measured number.
By their numbers in this assay, from the lowest: compounds 3, 1, 2 and 4 (each within the scatter of the next).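

Taking the aryl ring off this carbon altogether leaves the read-out flat: the step of a 1.1-fold higher number from compound 3 to compound 4 (0.06 log units; within the scatter) in this assay joins a 1.1-fold higher number from compound 2 to compound 4 (0.04 log units; within the scatter) and a 1.1-fold higher number from compound 1 to compound 4 (0.04 log units; within the scatter) in lying within the scatter. The earlier compounds shown here showed only that 4-methoxyphenyl, naphthalen-1-yl and 2-chlorophenyl could stand in for one another on this aromatic carbon opposite the ring nitrogen, whereas compound 4 shows that, across these four compounds, the read-out does not depend on an aryl ring being present there at all, since methyl serves equally well. Nothing available explains why such different groups at this position give matching numbers.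

As far as these compounds go, all four compounds carry either an aryl ring or methyl on this carbon, so it remains open whether a group of another kind, such as an amine, a carboxylic acid or a longer alkyl chain, would separate itself from them in this assay. All four also share the same core and its other methyl, so what a change elsewhere in the molecule would do to the read-out is equally unresolved.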